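The compounds below may be only part of what the source reports. "The series", "measured", "known", "first", "only" and "open" are said of these compounds alone.

Compound 1 `CCOc1ccc(-c2c(C#N)c(N)nc(SCc3ccn[nH]3)c2C#N)cc1` gives 332 nM in a functional assay on CHO cells for agonist activity at adenosine receptor A2b (Homo sapiens), read by AlphaScreen and cAMP accumulation (a higher number here means that more compound is needed for the effect, a lower number that less compound is needed), the highest of the three numbers measured there. Compound 2 `N#Cc1c(N)nc(SCc2ncn[nH]2)c(C#N)c1-c1ccc(OCC2CC2)cc1` gives 51 nM and compound 3 `N#Cc1c(N)nc(SCC(N)=O)c(C#N)c1-c1ccc(OCC2CC2)cc1` gives 31 nM; both steps from compound 1 lie beyond the scatter. Going by the values given here, the one measured step that alters the group on a saturated chain carbon bound to a sulfur, a 1.6-fold lower number from compound 2 to compound 3 (0.22 log units; within the scatter), stays within the scatter. Compound 4 `CCOc1ccc(-c2c(C#N)c(N)nc(SCc3ncc[nH]3)c2C#N)cc1` differs from compound 1 by 1H-imidazol-2-yl in place of 1H-pyrazol-5-yl on a saturated chain carbon bound to a sulfur. Among the compounds with values here, no measured step exchanges one five-membered aromatic ring for another at that place, so the account expects no step beyond the scatter, a 1.1-fold lower number from compound 1 to compound 4 (0.04 log units; within the scatter). Compound 4 is therefore estimated at 300 nM, with a range from 110 nM to 850 nM.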

Compound 4, half-maximal effective concentration: 11.7 nM
Compound 4: middle estimate off by 26-fold (1.41 log units), on the high side; measured number below the stated range.
By their numbers in this assay, from the lowest: compound 4; then compounds 3 and 2 (each within the scatter of the next); then compound 1.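

In this assay, the place on a saturated chain carbon bound to a sulfur responds strongly to how the ring is joined: 1H-imidazol-2-yl in place of 1H-pyrazol-5-yl gives a large step (a 28-fold lower number from compound 1 to compound 4 (1.45 log units; beyond the scatter)), although both groups have the same atoms and the same hydrogen-bond donor and acceptor counts. Going by these compounds alone, the earlier step at this place (a 1.6-fold lower number from compound 2 to compound 3 (0.22 log units; within the scatter)) stayed within the scatter, so only this step shows that the place can respond beyond it. No evidence on why these two rings differ is available.

The compounds shown leave open whether a 1H-imidazol-4-yl group or an amine at that place would stand nearer compound 4 or compound 1.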